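Shortening the chain of compound 2

The source may report more compounds than this note shows. Statements on the series, on what has been measured and on what is new or still open speak of the compounds shown alone.

Of the compounds shown here, two have so far been measured in a physicochemical assay for lipophilicity (a lower number here means a more polar compound, a higher number a more lipophilic compound), and both give high numbers. Compound 1 (`CCCCCCCCCCCCCCCCN1CCN(Cc2ccc(-c3noc(=O)[nH]3)cc2)CC1`) gives 6.34 in this measurement. Compound 2 (`CCCCCCCCCCCCCCCCCCN1CCN(Cc2ccc(Cc3noc(=O)[nH]3)cc2)CC1`) gives 7.67 as the higher of the two, and the gap between them lies beyond the scatter of repeated measurements.

Compound 3 (`CCCCCCCCCCCCCCCCN1CCN(Cc2ccc(Cc3noc(=O)[nH]3)cc2)CC1`) has not yet been measured. It differs from compound 2 in one place: hydrogen in place of ethyl on a saturated chain carbon, ten or more bonds along the chain from an amine nitrogen in a ring. Among the measured compounds shown here, no measured pair shows this change on its own, so the expectation rests on the structural change alone, starting from compound 2 at 7.67 on the scale. With carbon leaving and only hydrogen entering, a fall in this assay is expected. The expected step of a number 1.02 log units lower from compound 2 to compound 3 (beyond the scatter) is a fall beyond the scatter. Compound 3 is estimated at 6.65 within an expected range (6.3 to 7).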

Compound 3, partition coefficient: 6.63
Estimate against measurement, compound 3: 0.02 log units above, within the range that was stated.
By their numbers in this assay, from the lowest: compounds 1 and 3 (each within the scatter of the next); then compound 2.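

The change of ethyl to hydrogen on a saturated chain carbon now has a measured size in this assay, with a number 1.04 log units lower from compound 2 to compound 3 (beyond the scatter) as the first step read on its own at this place. Among the compounds shown here, with the chain held the same, the exchange of the group on the aromatic carbon gives only a number 0.29 log units higher from compound 1 to compound 3 (within the scatter), so of these two single changes, only the one on the chain moves the number beyond the scatter. Nothing measured alongside these numbers gives a reason for the size of either step.

The compounds shown give a single step on the chain, so it stays open whether further shortening would bring steps of like size, or whether a longer chain would bring a rise. As far as these compounds go, it is also open whether a carboxylic acid on the aromatic carbon, in place of the group carrying the five-membered aromatic ring, would stay as close to compound 3 in this assay as compound 1 does, and whether the chain step would hold on the core of compound 1.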